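Pyrazinyl replaces methoxyphenyl on a piperazine of compound 2

A few compounds are considered here, and "the series" means these few. Any claim that something is new, unique, unknown or untested is made for them only; others in the source may bear on it.

Three compounds with a shared core were tested in a functional assay on A-375 cells (Homo sapiens) for antiproliferative activity, read by CCK-8 assay, with a stated time of 72 h, tested at 2 uM; on this read-out lower numbers stand for a weaker effect and higher numbers for a stronger effect at the one concentration tested. Compound 1 `CN(C(=S)SCc1ccc(C(=O)Nc2ccccc2N)cc1)c1cccnc1` gives 26.5%, compound 2 `COc1ccc(N2CCN(C(=S)SCc3ccc(C(=O)Nc4ccccc4N)cc3)CC2)cc1` gives 28.1%, and compound 3 `Nc1ccccc1NC(=O)c1ccc(CSC(=S)N2CCCC2)cc1` gives 30.2%. Compound 2 sits second highest of the three, yet all three values lie within the scatter of one another. Among the compounds with values here, the single one-place step, a number 3.7 percentage points higher from compound 1 to compound 3 (within the scatter), concerns the thiocarbonyl carbon, not the amine nitrogen in a ring where compound 4 `Nc1ccccc1NC(=O)c1ccc(CSC(=S)N2CCN(c3cnccn3)CC2)cc1` departs from compound 2: pyrazin-2-yl in place of 4-methoxyphenyl on an amine nitrogen in a ring. No measured step bears on this change, and the one step shown stays within the scatter, so no step beyond the scatter is expected in this assay. Compound 4 is therefore estimated at 28%, between 15% and 41%. That corresponds to an expected a number 0.1 percentage points lower from compound 2 to compound 4 (within the scatter).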

Compound 4, a percentage reported as inhibition, at one concentration (the size of the read-out at that concentration, not a potency): 29.1%
Estimate against measurement, compound 4: 1.1 percentage points below, within the range that was stated.
By their numbers in this assay, from the lowest: compounds 1, 2, 4 and 3 (each within the scatter of the next).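

Pyrazin-2-yl in place of 4-methoxyphenyl on an amine nitrogen in a ring gives a number 1 percentage points higher from compound 2 to compound 4 (within the scatter) in this assay, the first step read at this position. Exchanging a ring of carbon only for one with 2 hetero atoms, and with fewer heavy atoms, thus leaves the read-out unchanged within the scatter. No evidence on any property of either group bears on this result.

Open, from the compounds shown here alone, is whether a carboxylic acid or a longer chain on this nitrogen would give a step beyond the scatter. Potency also stays open, since each compound was read at one concentration.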